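This account rests on a few compounds, and the source may have more. Where it says the series, first, only, none or still open, it means among the compounds named here.

Compound 1 `O=C(C(Nc1ccccc1F)c1ccc(C(F)(F)F)cc1)N1CCCC1c1ccccc1F` is measured in an assay on HEK293 cells for antagonist activity at transient receptor potential M8 protein (Canis lupus familiaris), read by fluorescence and calcium flux, with a stated time of 5 min (a lower number here means a stronger inhibitor, a higher number a weaker inhibitor), where compound 1 gives 7 nM. Compound 3 `O=C(C(Nc1ccccc1F)c1ccc(C(F)(F)F)cc1)N1CCCC1c1cccnc1` gives 7 nM in this assay, so there is no change at the digits printed from compound 1 to compound 3 (within the scatter). Compound 2 `COc1ccccc1C1CCCN1C(=O)C(Nc1ccccc1F)c1ccc(C(F)(F)F)cc1` gives 12 nM in this assay, and the step is a 1.7-fold higher number from compound 1 to compound 2 (0.23 log units; within the scatter). Compound 1 thus sits level with compound 3, with compound 2 within the scatter of both.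

Compound 4 `O=C(C(Nc1ccccc1F)c1ccc(C(F)(F)F)cc1)N1CCC[C@@H]1c1ccccc1F` differs from compound 1 in that (the two compounds have the same atoms and bonds; at least one stereo element is drawn with a configuration in one of them and without one in the other: 1 of 2 stereo elements differ; a stereocentre at a saturated ring carbon is drawn without a configuration in compound 1 and R in compound 4). Among the measured compounds shown here, none of the measured steps touches a stereocentre; each exchanges one ring for another, and none moves beyond the scatter. The data give no guide to which configuration carries the activity, so the expected step is a 1.2-fold lower number from compound 1 to compound 4 (0.07 log units; within the scatter) with a wide range. For compound 4 the estimate is 6 nM, between 2 nM and 60 nM.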

Compound 4, half-maximal inhibitory concentration: 44 nM
For compound 4 the middle estimate is 7.3-fold (0.87 log units) below the measured one; measured number inside the range.
By their numbers in this assay, from the lowest: compounds 1, 3 and 2 (each within the scatter of the next); then compound 4.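

In this assay, among the compounds shown here, the same atoms and bonds give a 6.3-fold higher number from compound 1 to compound 4 (0.80 log units; beyond the scatter), the first step here to lie beyond the scatter. The earlier exchanges of one ring for another at this saturated ring carbon all stayed within it, so the drawn configuration at this carbon matters more than those ring changes did. The only structural difference that can account for this step is: the fact that one of compounds 1 and 4 is drawn with a defined configuration and the other without, at the place where they differ

From the compounds shown here alone, whether the S configuration at this carbon would give a lower number than compound 1 remains open. So does the effect of a carboxylic acid or a simple amine in place of the ring at this carbon.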